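The source may hold more compounds than are shown below. What is called first, only, known or untested is meant among the compounds shown, and "the series" means these compounds.

Three compounds share one core. Compound 1 `COc1cc(-c2cc(-c3cccc([N+](=O)[O-])c3)nc(-c3ccccc3)n2)cc(OC)c1OC` in a functional assay on HCT-116 cells (Homo sapiens) for inhibition, read by MTT assay, with a stated time of 48 h (a higher number here means a weaker inhibitor, a lower number a stronger inhibitor), gives > 25000 nM, which is a limit of the assay rather than a number. Compound 2 `COc1ccc(-c2cc(-c3cc(OC)c(OC)c(OC)c3)nc(-c3ccccc3)n2)c(OC)c1` in this assay gives > 25000 nM, again a limit. Compound 3 `COc1cc(-c2cc(-c3ccccc3)nc(-c3ccccc3)n2)cc(OC)c1OC` in this assay gives 9950 nM. Compound 2 therefore stands at the limit of > 25000 nM in this assay, at which 2 of the 3 values shown sit, alongside compound 1, and compound 3 sits an at least 2.5-fold lower number from compound 2 to compound 3 (0.40 log units; beyond the scatter). Compound 4 `COc1cc(-c2cc(-c3ccc(N)cc3)nc(-c3ccccc3)n2)cc(OC)c1OC` differs from compound 2 by 4-aminophenyl in place of 2,4-dimethoxyphenyl on an aromatic carbon. The step of an at least 2.5-fold lower number from compound 2 to compound 3 (0.40 log units; beyond the scatter) bears on this change, since it also removes the 2,4-dimethoxyphenyl, and an at least 2.5-fold lower number from compound 1 to compound 3 (0.40 log units; beyond the scatter) shows a similar size when a substituent leaves the core. For compound 4 an improvement of an at least 2.7-fold lower number from compound 2 to compound 4 (0.44 log units; beyond the scatter) is expected. Compound 4 is estimated at 9000 nM, within a range of 2500 nM to 25000 nM.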

Compound 4, half-maximal inhibitory concentration: 12300 nM
Compound 4: the middle estimate sits 1.4-fold (0.14 log units) below what was measured, within the range that was stated.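

Compound 4 shows that an amino group on the phenyl at this aromatic carbon does not separate from plain phenyl in this assay: a 1.2-fold higher number from compound 3 to compound 4 (0.09 log units; within the scatter). Measured against the two compounds held at a limit, the readable floors are an at least 2.0-fold lower number from compound 2 to compound 4 (0.30 log units; that floor lies within the scatter) and an at least 2.0-fold lower number from compound 1 to compound 4 (0.30 log units; that floor lies within the scatter), so neither step alone establishes a gain beyond the scatter. Compound 1 and compound 2 remain limits of the assay: the limit of > 25000 nM in this assay, at which 2 of the 4 values shown sit.

As far as these compounds go, whether an acetamide, a hydroxyl or a carboxylic acid in place of the amino group would read differently from compound 3 in this assay stays open.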